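Replacing 4-nitrophenyl with pyridin-4-yl on the shared core

The source may hold more compounds than are shown below. What is called first, only, known or untested is meant among the compounds shown, and "the series" means these compounds.

Of the compounds shown here, three have been measured in a functional assay on MKN-45 cells (Homo sapiens) for cytotoxicity (a lower number here means a stronger inhibitor, a higher number a weaker inhibitor), so far. Compound 1 `COc1ccc(S(=O)(=O)N2CCc3cccc(NC(=O)C(C)(C)C)c32)cc1` gives 289 nM and compound 2 `COC(=O)c1ccc(C(=O)Nc2cccc3c2N(S(=O)(=O)c2ccc(OC)cc2)CC3)cc1` gives 312 nM while compound 3 `COc1ccc(S(=O)(=O)N2CCc3cccc(NC(=O)c4ccc([N+](=O)[O-])cc4)c32)cc1` gives 95 nM as the lowest number of the three.

Compound 4 `COc1ccc(S(=O)(=O)N2CCc3cccc(NC(=O)c4ccncc4)c32)cc1` has not yet been measured. Set against compound 3 it carries pyridin-4-yl in place of 4-nitrophenyl on a carbonyl carbon, and the change counts as pyridin-4-yl in place of 4-nitrophenyl on a carbonyl carbon with the rest of the structure untouched.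

Going by the values given here, three measured steps bear on this. Putting 4-(methoxycarbonyl)phenyl in place of tert-butyl gave a 1.1-fold higher number from compound 1 to compound 2 (0.03 log units; within the scatter) and so an aromatic group at that carbonyl did not by itself go with a lower number. Putting 4-nitrophenyl in place of tert-butyl gave a 3.0-fold lower number from compound 1 to compound 3 (0.48 log units; beyond the scatter) and nitro in place of methoxycarbonyl gave a 3.3-fold lower number from compound 2 to compound 3 (0.52 log units; beyond the scatter) so among these three the lower number goes with the nitro group. Among the compounds with values here, compound 4 has no nitro group, and no measured compound carries pyridin-4-yl. A modest step of similar size towards a higher number is therefore expected in this assay for this change. The estimated change is a 2.3-fold higher number from compound 3 to compound 4 (0.36 log units; beyond the scatter) with wide uncertainty. Compound 4 is estimated at 220 nM with an expected range from 80 nM to 600 nM on this read-out.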

Compound 4, half-maximal inhibitory concentration: 8.8 nM
Compound 4: the middle estimate sits 25-fold (1.40 log units) above what was measured, outside the stated range (below it).
By their numbers in this assay, from the lowest: compound 4; then compound 3; then compounds 1 and 2 (each within the scatter of the next).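

In this assay, going by these compounds alone, the steps among the earlier compounds at this carbonyl carbon were modest or within the scatter, whereas pyridin-4-yl in place of 4-nitrophenyl gives an 11-fold lower number from compound 3 to compound 4 (1.03 log units; beyond the scatter), a large step. The same group also stands well clear of the other two substituents, with a 35-fold lower number from compound 2 to compound 4 (1.55 log units; beyond the scatter) and a 33-fold lower number from compound 1 to compound 4 (1.52 log units; beyond the scatter), so compound 4 has the lowest number of the four and the earlier link between the nitro group and a lower number no longer describes the whole set. Among the three compounds with an aromatic ring at this carbonyl, the lowest number goes with the only ring holding a hetero atom, which is also the group with the fewest heavy atoms, although this rests on compound 4 alone.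

No measurement shown here accounts for the size of this step. The compounds leave open whether the lower number goes with the ring nitrogen, its place in the ring, or the loss of the ring substituent; plain phenyl and pyridin-3-yl on the same carbonyl carbon would help separate these readings.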